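The source may hold more compounds than are shown below. What is called first, only, known or untested is meant among the compounds shown, and "the series" means these compounds.

Measured compounds:
compound 1 `COc1cc(C(c2ccc(O)c(OC)c2)[C@@H](C)[C@@H](C)CO)ccc1O`, > 100000 nM
compound 2 `COc1cc(C(c2ccc(O)c(OC)c2)[C@H](CF)C(C)C)ccc1O`, 19000 nM
compound 3 `COC[C@@H](C(C)C)C(c1ccc(O)c(OC)c1)c1ccc(O)c(OC)c1`, 69000 nM

In a functional assay on HeLa cells (Homo sapiens) for cytotoxicity, read by WST assay, with a stated time of 48 h (a lower number here means a stronger inhibitor, a higher number a weaker inhibitor), compound 1 sits at the limit of > 100000 nM in this assay, at which 1 of the 3 values shown sits, so only a limit and not a number is known for it. Compound 2 gives 19000 nM in this assay. Compound 3 gives 69000 nM in this assay.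

Compound 4 `COc1cc(C(c2ccc(O)c(OC)c2)[C@H](CC(C)C)C(C)C)ccc1O` is not yet measured. Its change from compound 1 is 1-isopropyl-3-methylbutyl in place of 2-(hydroxymethyl)-1-methylpropyl on a saturated chain carbon bound to two aromatic carbons.

Two measured steps start from compound 1 and alter the same chain: an at least 5.2-fold lower number from compound 1 to compound 2 (0.72 log units; beyond the scatter) and an at least 1.4-fold lower number from compound 1 to compound 3 (0.16 log units; that floor lies within the scatter). The two products are separated by a 3.6-fold higher number from compound 2 to compound 3 (0.56 log units; beyond the scatter). Both steps remove the hydroxyl donor of the chain and both point to a lower number, one of them clearly. Compound 4 also loses that hydroxyl and gains carbon only, so a move in the same direction, at least modest and in the region of compound 2, is expected. Compound 4 is therefore estimated at 15000 nM, with a range from 4000 nM to 60000 nM. That estimate means an expected at least 6.6-fold lower number from compound 1 to compound 4 (0.82 log units; beyond the scatter).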

Compound 4, half-maximal inhibitory concentration: 8200 nM
Compound 4: middle estimate off by 1.8-fold (0.26 log units), on the high side, and the stated range covers the measured number.
By their numbers in this assay, from the lowest: compound 4; then compound 2; then compound 3. At a limit, above all of these: compound 1.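

In this assay, compound 4 now has the lowest number of the compounds shown, with an 8.4-fold lower number from compound 3 to compound 4 (0.93 log units; beyond the scatter) and a 2.3-fold lower number from compound 2 to compound 4 (0.36 log units; beyond the scatter). On a saturated chain carbon bound to two aromatic carbons, the series therefore reaches its lowest number with an all-carbon chain, 1-isopropyl-3-methylbutyl, which holds neither the oxygen of compound 3 nor the fluorine of compound 2. The widest step, an at least 12-fold lower number from compound 1 to compound 4 (1.08 log units; beyond the scatter), gives a floor and not a size: the limit of > 100000 nM in this assay, at which 1 of the 4 values shown sits.

As far as these compounds go, it remains open whether a longer chain, a phenyl ring or an amine at this same place would lower the number further or raise it. Compound 4 differs from compound 1 both in losing the hydroxyl and in the size of its chain, so the compounds shown do not separate these two changes.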